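The source may report more compounds than this note shows. Statements on the series, on what has been measured and on what is new or still open speak of the compounds shown alone.

Measured compounds:
Compound 1, `Cc1c(OCCCCOc2ccccc2C(=O)O)ccc(C(=O)CC(C)C)c1O`, gives 415 nM in an assay on HEK293 cells for positive allosteric modulation of metabotropic glutamate receptor 2 (Rattus norvegicus), read by thallium flux, with a stated time of 2.5 min; a higher number here means that more compound is needed for the effect, a lower number that less compound is needed.
Compound 2, `Cc1c(OCCCCOc2ccc(F)c(C(=O)O)c2)ccc(C(=O)CC2CCCC2)c1O`, gives 699 nM in this assay.
Compound 3, `Cc1c(OCCCCOCOc2ccc(C(=O)O)cc2)ccc(C(=O)CC2CCCC2)c1O`, gives 228 nM in this assay.

Compound 1 stands second highest of the three numbers; compound 2 is within the scatter of it, and compound 3 is also within the scatter of it, so no order can be read among them. Among the compounds with values here, the only step beyond the scatter in the set is a 3.1-fold lower number from compound 2 to compound 3 (0.49 log units; beyond the scatter), which exchanges both the carboxyphenyl pattern and the linker, so it does not isolate the placement of the carboxylic acid on the ring.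

Compound 4, `Cc1c(OCCCCOc2cccc(C(=O)O)c2)ccc(C(=O)CC(C)C)c1O`, differs from compound 1 in one place: 3-carboxyphenyl in place of 2-carboxyphenyl on an oxygen on a saturated carbon. Within the data shown here, no measured pair bears directly on this change; the step from compound 2 to compound 3 is the nearest comparison and is only modest. A step no larger than the scatter is therefore expected in this assay, with no direction favoured. The expected step is a 1.1-fold lower number from compound 1 to compound 4 (0.04 log units; within the scatter). Compound 4 is estimated at 380 nM, with a range from 130 nM to 1100 nM.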

Compound 4, half-maximal effective concentration: 222 nM
Estimate against measurement, compound 4: 1.7-fold (0.23 log units) above; low and high end bracket the measured number.
By their numbers in this assay, from the lowest: compounds 4, 3, 1 and 2 (each within the scatter of the next, the first and the last beyond it).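

Within the data shown here, with compound 4, the placement of the carboxylic acid on the phenyl ring can be read for the first time as a change in one place, with the rest of the molecule held constant. In this assay, 3-carboxyphenyl in place of 2-carboxyphenyl on an oxygen on a saturated carbon gives a 1.9-fold lower number from compound 1 to compound 4 (0.27 log units; within the scatter) and so does not separate the two placements; the acid is tolerated in either one, a reading that rests on this single pair. Nothing available here accounts for this result.

Still open, going by these compounds, is how 4-carboxyphenyl would compare in the same place on the core of compound 1, and whether the reading holds with the cyclopentyl ketone of compounds 2 and 3. Also open, on these data alone, is whether the carboxylic acid can give way to a tetrazole or a primary amide on the same ring.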